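The compounds below may be only part of what the source reports. "The series", "measured", "known", "first", "only" and "open" are said of these compounds alone.

Measured compounds:
- Compound 1, `NC(=O)CCNC(=O)c1cccc(S)c1`: > 100 uM in an ADME assay on CEM-SS cells (Homo sapiens) for cytotoxicity, read by XTT assay, with a stated time of 6 days; a lower number here means that less compound is tolerated, a higher number that more compound is tolerated
- Compound 2, `CCCC(=O)OCSc1ccccc1C(=O)NCCCCNC(C)=O`: 17.4 uM in this assay

Compound 1 returns only a limit in this assay, reported as > 100 uM. Among the compounds with values here, compound 2 is the one compound with a number in this assay, at 17.4 uM, and it therefore stands alone in the ranking. Within the data shown here, the value of compound 1 is a limit, (the limit of > 100 uM in this assay, at which 1 of the 2 values shown sits), so no step between measured compounds can be read.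

Compound 3, `CCCC(=O)OCSc1ccccc1C(=O)NCC(=O)NCC(N)=O`, differs from compound 2 as follows: (carbamoylmethyl)carbamoyl in place of 3-acetamidopropyl on a saturated chain carbon bound to an amide-type nitrogen. Among the measured compounds shown here, with no measured step to lean on, the change from compound 2 to compound 3 is expected to give a moderate rise in tolerated concentration, a 2.3-fold higher number from compound 2 to compound 3 (0.36 log units; beyond the scatter), though a result inside the usual scatter would not surprise. Compound 3 is accordingly estimated at 40 uM in this assay, with a range from 15 uM to 100 uM.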

Compound 3, half-maximal toxic concentration: > 100 uM
Compound 3: a limit, no number; the forecaster's own chance of this, stated with the estimate: 30%; middle value at least 2.5-fold (0.39 log units) away from the limit.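

In this assay, within the data shown here, putting (carbamoylmethyl)carbamoyl in place of 3-acetamidopropyl on a saturated chain carbon bound to an amide-type nitrogen gives an at least 5.7-fold higher number from compound 2 to compound 3 (0.75 log units; beyond the scatter), the first readable step. The two structures differ in this one place only, so this side chain alone is enough to move the result beyond the scatter. The full size of the step remains unknown because compound 3 gives only a limit: the limit of > 100 uM in this assay, at which 2 of the 3 values shown sit.

On these data alone, it remains open which part of the entering group carries the step, as the change replaces the whole chain at once. As far as these compounds go, it also remains open whether a longer alkyl chain, an amine or a carboxylic acid in this place would give a measurable number in this assay or also reach the limit.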